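Removing the terminal phenyl from a spirocyclic sigma-1 ligand

The source may hold more compounds than are shown below. What is called first, only, known or untested is meant among the compounds shown, and "the series" means these compounds.

Measured compounds:
compound 1, `COC1Cc2sc(-c3ccccc3)cc2C2(CCN(Cc3ccccc3)CC2)O1`, 5.5 nM
compound 2, `COC1Cc2sc(-c3ccc(-c4ccccc4)cc3)cc2C2(CCN(Cc3ccccc3)CC2)O1`, 220 nM
compound 3, `c1ccc(CN2CCC3(CC2)OCCc2c(-c4ccccc4)csc23)cc1`, 1.6 nM

Of the compounds shown here, three built on a closely related spirocyclic core have been tested in an assay on membranes from brain for displacement of a labelled ligand from Sigma non-opioid intracellular receptor 1 (Cavia porcellus), read by scintillation counting, with a stated time of 120 min; a lower number here means a stronger inhibitor, a higher number a weaker inhibitor. Compound 3 gives 1.6 nM, the lowest of the three numbers. Compound 1 gives 5.5 nM, and compound 2 gives 220 nM. Compound 1 and compound 2 differ in one place only, (hydrogen in place of phenyl on an aromatic carbon), and the step of a 40-fold lower number from compound 2 to compound 1 (1.60 log units; beyond the scatter) is large. How the core of compound 3 differs from that of compound 2 is not broken down here.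

Compound 4, `c1ccc(CN2CCC3(CC2)OCCc2ccsc23)cc1`, has not yet been measured in this assay. It differs from compound 3 by hydrogen in place of phenyl on an aromatic carbon. Within the data shown here, this is the same kind of change as the one from compound 2 to compound 1, but not the same: there the phenyl left an aromatic carbon of a six-membered aromatic ring of carbon only, para to a large group, whereas here it leaves an aromatic carbon of a five-membered aromatic ring with one sulfur, part of a fused system of three rings, next to the ring atom that bears a fused ring and two ring bonds from the ring sulfur. Because a 40-fold lower number from compound 2 to compound 1 (1.60 log units; beyond the scatter) shows that losing a phenyl at the far end of the molecule helped strongly in that pair, one might hope for a similar gain; but in compound 4 the group that leaves is the only aromatic ring on that side of the core, so the step is expected to go the other way, with a 9.4-fold higher number from compound 3 to compound 4 (0.97 log units; beyond the scatter) as the estimate. Compound 4 is thus estimated at 15 nM, within 3 nM to 80 nM.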

Compound 4, inhibition constant: 1 nM
Compound 4: the middle estimate sits 15-fold (1.18 log units) above what was measured; the measured number lies below the stated range.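

In this assay, putting hydrogen in place of phenyl on an aromatic carbon of a five-membered aromatic ring with one sulfur gives a 1.6-fold lower number from compound 3 to compound 4 (0.20 log units; within the scatter), so on this core the phenyl can go with no change that rises above the usual scatter of the measurement. Set beside the earlier pair, the same named change clearly does not carry a fixed size from one core to another in this series: the same change on two cores in this assay, a 40-fold lower number (1.60 log units; beyond the scatter) from compound 2 to compound 1 and a 1.6-fold lower number (0.20 log units; within the scatter) from compound 3 to compound 4, 25-fold (1.40 log units) apart, beyond the scatter of two such steps. This does not show why the two steps differ, since the phenyl leaves a different kind of ring at a different place on a different core in each pair, and two pairs cannot separate these factors or give a rule for a further core.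

The compounds shown leave open whether a group other than phenyl or hydrogen on that aromatic carbon, such as methyl, chlorine or an amine, would shift the number on the core of compound 4. They also leave open how that core responds when the benzyl group on the ring nitrogen gives way to a longer chain, such as phenylbutyl, and how the two pairs would read at any other receptor.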